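Pyridazin-3-yl in place of acetyl: what compound 3 may show

The compounds below may be only part of what the source reports. "The series", "measured", "known", "first", "only" and "open" are said of these compounds alone.

Measured in an ADME assay on cells (Hepatocyte, Homo sapiens) for metabolic stability; a lower number here means that the compound disappears faster, a higher number that the compound lasts longer:
Compound 1 `O=C(C1CCN(c2ncccn2)CC1)N1N=CC[C@H]1c1ccccc1`: > 3.11 h (a limit)
Compound 2 `CC(=O)N1CCC(C(=O)N2N=CC[C@H]2c2ccccc2)CC1`: > 3.11 h (a limit)

In this assay compound 2 stands at > 3.11 h, which is a limit and not a number. Compound 1 gives > 3.11 h, also a limit. The measured pair offers only (the limit of > 3.11 h in this assay, at which 2 of the 2 values shown sit).

Compound 3 `O=C(C1CCN(c2cccnn2)CC1)N1N=CC[C@H]1c1ccccc1` has not yet been measured. It differs from compound 2 by pyridazin-3-yl in place of acetyl on an amine nitrogen in a ring. Among the measured compounds shown here, the one measured step at this nitrogen is a step that the two limits leave unreadable from compound 1 to compound 2, where acetyl takes the place of pyrimidin-2-yl. Its size cannot be read, so it gives no direction and no measure for the new change. With neither compound showing a number, no step beyond the scatter is expected, and compound 3 will quite possibly also be reported as a limit. The expected step is a number no higher from compound 2 to compound 3 (the limit leaves the size open). For compound 3 the estimated half-life is 3.1 h, with an expected range from 1.5 h to 5.5 h.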

Compound 3, half-life: 2.32 h
For compound 3 the middle estimate is 1.3-fold (0.13 log units) above the measured one; the measured number falls inside the stated range.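

In this assay compound 3 is the first compound here to give a number and not a limit, and the other two values remain limits: the limit of > 3.11 h in this assay, at which 2 of the 3 values shown sit.

Pyridazin-3-yl in place of acetyl gives an at least 1.3-fold lower number from compound 2 to compound 3 (0.12 log units; that floor lies within the scatter), and pyridazin-3-yl in place of pyrimidin-2-yl gives an at least 1.3-fold lower number from compound 1 to compound 3 (0.12 log units; that floor lies within the scatter). Both steps can be larger than these floors, but as printed neither floor goes beyond the scatter, so the substituent on this amine nitrogen has not yet been shown to matter, while the step between compound 1 and compound 2 still cannot be read.

The compounds shown leave open how far compound 1 and compound 2 actually lie from compound 3, and they give no measured property that could account for any difference among the three groups on this nitrogen. They also leave open whether a plain phenyl ring or a methanesulfonyl group at the same place would give a number or a limit.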